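Aryl swap on the enone chain of the shared core

The compounds below may be only part of what the source reports. "The series", "measured", "known", "first", "only" and "open" are said of these compounds alone.

Compound 1 `CNC(=O)c1cc(Oc2ccc(/C=C/C(=O)c3ccc([N+](=O)[O-])cc3)cc2)ccn1` carries the shared core, and in a functional assay on A549 cells (Homo sapiens) for cytotoxicity, read by MTT assay, with a stated time of 72 h (a lower number here means a stronger inhibitor, a higher number a weaker inhibitor), compound 1 has "not determined" (no result reported). Compound 2 `CNC(=O)c1cc(Oc2ccc(C(=O)/C=C/c3cc(OC)c(OC)c(OC)c3)cc2)ccn1` gives 9500 nM in this assay. Compound 3 `CNC(=O)c1cc(Oc2ccc(C(=O)/C=C/c3ccc(Cl)cc3Cl)cc2)ccn1` gives 9460 nM and stands at the low end of the two numbers, yet its gap to compound 2 lies within the scatter, so neither compound ranks above the other. Compound 4 `CNC(=O)c1cc(Oc2ccc(C(=O)/C=C/c3ccc(OC)cc3)cc2)ccn1` is the next structure: 4-methoxyphenyl in place of 2,4-dichlorophenyl on a double-bonded chain carbon bound to a double-bonded chain carbon. Going by the values given here, no step between measured compounds covers this change, and the two numbers so far sit close together despite quite different aryl groups on the chain. The expected step is a 1.1-fold higher number from compound 3 to compound 4 (0.02 log units; within the scatter), small and not beyond the scatter. Compound 4 is therefore estimated at 10000 nM in this assay, with a range from 4000 nM to 25000 nM.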

Compound 4, half-maximal inhibitory concentration: > 50000 nM
Compound 4: only a limit was reported; the forecaster's own chance of this, stated with the estimate: 10%; middle value at least 5.0-fold (0.69 log units) away from the limit.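

The aryl group on this chain position does matter, although compounds 2 and 3 alone gave no sign of it: replacing 2,4-dichlorophenyl with 4-methoxyphenyl gives an at least 5.2-fold higher number from compound 3 to compound 4 (0.72 log units; beyond the scatter). For compound 4, > 50000 nM in this assay is a limit of the assay, not a number. Methoxy on this aryl group does not by itself go with the loss, since compound 2 also carries methoxy groups and gives 9500 nM.

From the compounds shown here alone, whether the step follows the chlorines leaving or the methoxy entering stays open. So does how an amine or a carboxylic acid on this aryl group would read in this assay.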